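Removing the Hydroxy from an Inactive Compound

The compounds below may be only part of what the source reports. "The series", "measured", "known", "first", "only" and "open" are said of these compounds alone.

Measured in a functional assay for inhibition, with Sus scrofa as the target; a lower number here means a stronger inhibitor, a higher number a weaker inhibitor:
- Compound 1 `CC1(C)Oc2ccc(C#N)cc2[C@@H](n2ccccc2=O)[C@@H]1O`: 300 nM
- Compound 2 `CC1(C)Oc2ccc(C#N)cc2[C@@H](n2ccccc2=O)[C@]1(C)O`: > 100000 nM (a limit)
- Compound 3 `CC1(C)Oc2ccc(C#N)cc2[C@@H](OC2=CC(=O)CC2)[C@]1(C)O`: 20 nM

Compound 2 stands at the limit of > 100000 nM in this assay, at which 1 of the 3 values shown sits, so it has a limit and no exact number. Compound 4 `C[C@H]1[C@H](n2ccccc2=O)c2cc(C#N)ccc2OC1(C)C` differs from it in one place: hydrogen in place of hydroxy on a saturated ring carbon. Among the measured compounds shown here, no measured step removes this hydroxy. For the measured compounds named here, the only measured step, an at least 5000-fold lower number from compound 2 to compound 3 (3.69 log units; beyond the scatter), was large, but it changed a different group. Since compound 4 keeps the group that an at least 5000-fold lower number from compound 2 to compound 3 (3.69 log units; beyond the scatter) replaced, it is expected to stay a weak inhibitor. Only a small shift towards lower numbers is expected in this assay, estimated as an at least 2.0-fold lower number from compound 2 to compound 4 (0.30 log units; that floor lies within the scatter). The estimate for compound 4 is 50000 nM, with an expected range from 5000 nM to 100000 nM.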

Compound 4, half-maximal inhibitory concentration: > 100000 nM
Compound 4 ended at the assay's limit (the forecaster's own chance of this, stated with the estimate: 55%); at least 2.0-fold (0.30 log units) between middle value and limit.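

In this assay the step from compound 2 to compound 4 cannot be read, since both sit at a limit: the limit of > 100000 nM in this assay, at which 2 of the 4 values shown sit.

Removing the hydroxy therefore did not bring compound 4 off that limit, so the hydroxy alone does not account for the weakness of compound 2. Methyl in place of hydroxy on this saturated ring carbon gives an at least 330-fold higher number from compound 1 to compound 4 (2.52 log units; beyond the scatter), a large loss of inhibition.

On these data alone, whether an amine or a methoxy on this carbon would restore inhibition remains open. So does how compound 4 would behave carrying the group of compound 3.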